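Changing One Side Group on a Shared Core

This account rests on a few compounds, and the source may have more. Where it says the series, first, only, none or still open, it means among the compounds named here.

In a physicochemical assay for acid dissociation, compound 1 `COc1cccc(CNCCCNc2ccnc3cc(-c4ccccc4)ccc23)c1O` gives 9.47 and compound 2 `COc1ccccc1Oc1ccc2c(NCCCNCc3cccc(OC)c3O)ccnc2c1` gives 9.28. Among the compounds with values here, these are the only two numbers so far, and they lie within the scatter of each other, so compound 2 cannot be told apart from compound 1 here.

Compound 3 `COc1cccc(CNCCCNc2ccnc3cc(CC4CCCCC4)ccc23)c1O` has not yet been measured. It differs from compound 2 by having cyclohexylmethyl in place of 2-methoxyphenoxy on an aromatic carbon, and the rest of the molecule stays the same: cyclohexylmethyl in place of 2-methoxyphenoxy on an aromatic carbon.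

One measured step involves the same place on the molecule. Within the data shown here, with 2-methoxyphenoxy in place of phenyl, it shows a number 0.19 log units lower from compound 1 to compound 2 (within the scatter), and it is the only guide available. Among the measured compounds shown here, no measured compound carries cyclohexylmethyl, so that guide is a thin one and the range has to stay wide.

The estimated change is a number 0.12 log units higher from compound 2 to compound 3 (within the scatter), and no step beyond the scatter is expected in this assay. For compound 3 the expected value is 9.4, with an estimated range from 9 to 9.8.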

Compound 3, acid dissociation constant: 9.47
The estimate for compound 3 lay 0.07 log units below the measured number; measured number inside the range.
By their numbers in this assay, from the lowest: compounds 2, 1 and 3 (each within the scatter of the next).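

In this assay, putting cyclohexylmethyl on this aromatic carbon gives a number 0.19 log units higher from compound 2 to compound 3 (within the scatter) and, set against phenyl, gives no change at the digits printed from compound 1 to compound 3 (within the scatter) for the same position. The result extends the picture from two groups to three: the new group has a non-aromatic ring where the other two have an aromatic one, and it has 0 hydrogen-bond acceptors where 2-methoxyphenoxy has 2, yet compound 3 cannot be told apart from compound 1 or compound 2 in this read-out. No measurement is available to explain why these differences in the group leave the three compounds inseparable here.

All three groups at this position carry a six-membered ring and no net charge, so the compounds shown leave open what an amine or a carboxylic acid on the same carbon would give. They also leave open whether a single fluorine atom, or a longer chain ending in an amine, would produce a step beyond the scatter in this assay at this aromatic carbon of the shared core.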